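This account rests on a few compounds, and the source may have more. Where it says the series, first, only, none or still open, it means among the compounds named here.

Series notes. Within the data shown here, compound 3 `CCOC(=O)C1=C(Nc2ccccc2)S/C(=C\c2cc3cccnc3[nH]2)C1=O` gives 54.3% in a functional assay on JAR cells (Homo sapiens) for inhibition, read by MTT assay, with a stated time of 72 h, tested at 10 uM (a lower number here means less inhibition, a higher number more inhibition at the concentration tested (going by the name of the read-out)), the highest of the three numbers measured so far. Compound 2 `CCOC(=O)C1=C(Nc2ccccc2)S/C(=C\c2cccnc2)C1=O` gives 32.1% in this assay, and compound 1 `CCOC(=O)C1=C(Nc2ccccc2)S/C(=C\c2ccccc2)C1=O` gives 20.3% in this assay; the steps up to compound 3 are a number 22.2 percentage points higher from compound 2 to compound 3 (beyond the scatter) and a number 34 percentage points higher from compound 1 to compound 3 (beyond the scatter), both beyond the scatter. The remaining measured step, a number 11.8 percentage points higher from compound 1 to compound 2 (beyond the scatter), is pyridin-3-yl in place of phenyl on the double-bonded chain carbon bound to the double-bonded ring carbon.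

Compound 4 `CCOC(=O)C1=C(Nc2ccccc2)S/C(=C\c2cc3cnccc3[nH]2)C1=O` has the same atoms as compound 3, joined differently: a group of 9 heavy atoms (7 carbon, 2 nitrogen; one five-membered aromatic ring with 1 hetero atom, one six-membered aromatic ring with 1 hetero atom) in place of a group of 9 heavy atoms (7 carbon, 2 nitrogen; one five-membered aromatic ring with 1 hetero atom, one six-membered aromatic ring with 1 hetero atom), on a double-bonded chain carbon bound to a double-bonded ring carbon. Among the measured compounds shown here, no measured step rearranges a ring group while keeping its atom count; all three measured steps exchange one ring group for a different one, and each raised the inhibition. For the measured compounds named here, those steps bear on compound 4 only loosely, in showing that the group present in compound 3 goes with the highest number in this assay so far. With nothing to indicate the direction of the rearrangement, the expected step for compound 4 is a number 4.3 percentage points lower from compound 3 to compound 4 (within the scatter), none beyond the scatter, with wide uncertainty. Compound 4 is therefore estimated at 50% in this assay, with a range from 25% to 70%.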

Compound 4, a percentage reported as inhibition, at one concentration (the size of the read-out at that concentration, not a potency): < 10%
Compound 4: only a limit was reported (the forecaster's own chance of this, stated with the estimate: 0%); middle value at least 40 percentage points from the limit.
By their numbers in this assay, from the lowest: compound 1; then compound 2; then compound 3. At a limit, below all of these: compound 4.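

Joining the same atoms differently at this place, on a double-bonded chain carbon bound to a double-bonded ring carbon, gives a number at least 44.3 percentage points lower from compound 3 to compound 4 (beyond the scatter), with the counted donors and acceptors unchanged, so the number in this series depends on how the atoms of the group are joined and not only on which atoms it holds. The earlier steps shown here all raised the number as one ring group replaced another, but the two-ring group that enters here does not keep that gain, giving a number at least 22.1 percentage points lower from compound 2 to compound 4 (beyond the scatter) and a number at least 10.3 percentage points lower from compound 1 to compound 4 (beyond the scatter), so having two rings at this place does not by itself go with more inhibition. For compound 4, the result in this assay is a limit and not a number: the limit of < 10% in this assay, at which 1 of the 4 values shown sits.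

What the compounds shown leave open is why the rearrangement costs so much, as two arrangements of this group cannot separate the place of the ring nitrogen from any other difference between them. Also open, going by these compounds, is how an amine or a carboxylic acid carried on the two-ring group of compound 3 would read in this assay.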